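A few compounds are considered here, and "the series" means these few. Any claim that something is new, unique, unknown or untested is made for them only; others in the source may bear on it.

Compound 1 `Cc1ccc(Cn2cc(COc3ccc4c(=O)ccoc4c3)nn2)cc1` gives 50700 nM in a functional assay on A549 cells (Homo sapiens) for cytotoxicity, read by MTT assay, with a stated time of 48 h; a higher number here means a weaker inhibitor, a lower number a stronger inhibitor.
Compound 2 `O=c1ccoc2cc(OCc3cn(Cc4ccc(Cl)cc4)nn3)ccc12` gives > 100000 nM in this assay, a limit of the assay.
Compound 3 `O=c1ccoc2cc(OCc3cn(Cc4ccc(F)cc4)nn3)ccc12` gives > 100000 nM in this assay, a limit of the assay.

Compound 3 thus stands only as a limit, one of the two values sitting at the limit of > 100000 nM in this assay, at which 2 of the 3 values shown sit, and only compound 1 yields a number. Compound 4 `CC(C)(C)c1ccc(Cn2cc(COc3ccc4c(=O)ccoc4c3)nn2)cc1` differs from compound 3 by tert-butyl in place of fluoro on an aromatic carbon. Among the measured compounds shown here, the steps that bear on it are an at least 1.9-fold higher number from compound 1 to compound 3 (0.29 log units; that floor lies within the scatter), which runs the opposite way (halogen for alkyl) and whose floor lies within the scatter, and a step that the two limits leave unreadable from compound 2 to compound 3, which cannot be sized. For the measured compounds named here, no measured step fixes a size; from compound 3 a step of an at least 1.6-fold lower number from compound 3 to compound 4 (0.22 log units; that floor lies within the scatter) is expected, toward a somewhat lower number if anything. Compound 4 is therefore estimated at 60000 nM, between 20000 nM and 150000 nM.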

Compound 4, half-maximal inhibitory concentration: > 100000 nM
Compound 4: only a limit was reported; the forecaster's own chance of this, stated with the estimate: 45%; middle value at least 1.6-fold (0.22 log units) away from the limit.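

In this assay, tert-butyl on this aromatic carbon, para to a large group, gives only a limit, as chloro and fluoro do, so a larger alkyl group does not retain a readable number here. Against methyl the change gives an at least 1.9-fold higher number from compound 1 to compound 4 (0.29 log units; that floor lies within the scatter), so even this comparison has only a floor. The steps among compound 2, compound 3 and compound 4 cannot be read, all three standing at a limit: the limit of > 100000 nM in this assay, at which 3 of the 4 values shown sit.

As far as these compounds go, how an amine or a carboxylic acid at this position would read in this assay remains open. Also open, from the compounds shown here alone, is whether any group here gives a number clearly lower than that of compound 1.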